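One Fluoro Group Added to Compound 2

The source may hold more compounds than are shown below. What is called first, only, known or untested is meant among the compounds shown, and "the series" means these compounds.

In an ADME assay on Vero cells (Chlorocebus sabaeus) for cytotoxicity, read by MTT assay, with a stated time of 72 h (on this read-out lower numbers stand for higher toxicity in this test and higher numbers for lower toxicity in this test), compound 1 (`CC1=C(/C=C/C(=O)/C=C/c2ccc(-n3cncn3)cc2)C(C)(C)CCC1`) gives 72400 nM and compound 2 (`CC1=C(/C=C/C2=NN(c3ccccc3)C(c3ccc(-n4cncn4)cc3)C2)C(C)(C)CCC1`) gives 112000 nM on the same scale. These two values lie within the usual scatter of each other, so compound 2 stands level with compound 1. Compound 3 (`CC1=C(/C=C/C2=NN(c3ccc(F)cc3)C(c3ccc(-n4cncn4)cc3)C2)C(C)(C)CCC1`) differs from compound 2 in one place (fluoro in place of hydrogen on an aromatic carbon), with fluoro in place of hydrogen on an aromatic carbon. For the measured compounds named here, no measured pair shows this kind of change, so no step beyond the scatter is expected in this assay here. The expected change is small (a 1.1-fold lower number from compound 2 to compound 3 (0.05 log units; within the scatter)). For compound 3 the expected value is 100000 nM (estimated range 50000 nM to 200000 nM).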

Compound 3, half-maximal cytotoxic concentration: 58600 nM
For compound 3 the middle estimate is 1.7-fold (0.23 log units) above the measured one, within the range that was stated.
By their numbers in this assay, from the lowest: compounds 3, 1 and 2 (each within the scatter of the next).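

Phenyl to 4-fluorophenyl is the first one-place change available in this series, and this assay shows a 1.9-fold lower number from compound 2 to compound 3 (0.28 log units; within the scatter) for it. This aromatic carbon, para to a large group, therefore accepts a fluoro without a step beyond the scatter, although one compound pair cannot establish a general pattern. No measurement here bears on the reason for this result. As far as these compounds go, whether a chloro, a methoxy or an amine at this same place would give a step beyond the scatter stays open.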